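The compounds below may be only part of what the source reports. "The series", "measured", "known", "first", "only" and "open" are said of these compounds alone.

Measured in a functional assay on PC-3 cells (Homo sapiens) for antiproliferative activity, read by CCK-8 assay, with a stated time of 6 days; on this read-out higher numbers stand for weaker inhibition and lower numbers for stronger inhibition:
- Compound 1 `CCN(c1ccc(C#N)c(Cl)c1)c1cc(-c2cncnc2)ccc1C`: > 30000 nM, a limit
- Compound 2 `CCN(c1ccc(C#N)c(Cl)c1)c1cc(-c2cccs2)ccc1C`: > 30000 nM, a limit
- Compound 3 `CCN(c1ccc(C#N)c(Cl)c1)c1cc(-n2ccnc2)ccc1C`: > 30000 nM, a limit

Compound 3 has no exact number, only a limit, > 30000 nM. The other two compounds are in the same position, so the series offers no numerical ranking: the limit of > 30000 nM in this assay, at which 3 of the 3 values shown sit.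

The next compound, compound 4 `CCN(c1ccc(C#N)c(Cl)c1)c1cc(-c2cn[nH]c2)ccc1C`, changes a single group: 1H-pyrazol-4-yl in place of 1H-imidazol-1-yl on an aromatic carbon. The two compounds have the same atoms, joined differently. The new group still sits on an aromatic carbon, para to a methyl group.

Within the data shown here, three measured steps bear on this change: a step that the two limits leave unreadable from compound 1 to compound 2, a step that the two limits leave unreadable from compound 1 to compound 3 and a step that the two limits leave unreadable from compound 2 to compound 3. Each swaps one ring on an aromatic carbon for another, but none has a readable size. They therefore offer no measured effect to carry over, and they point in no direction. All three rings tried so far ended at the same limit, as the limit of > 30000 nM in this assay, at which 3 of the 3 values shown sit, records, so the plainest expectation is that compound 4 stays near it. The 1H-pyrazol-4-yl group has not yet been tested here, so a modest gain in this assay remains possible.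

The expected change is a number no higher from compound 3 to compound 4 (the limit leaves the size open).

For compound 4 the estimate is 30000 nM, with an expected range from 8000 nM to 60000 nM.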

Compound 4, half-maximal inhibitory concentration: 15300 nM
Compound 4: middle estimate off by 2.0-fold (0.29 log units), on the high side; low and high end bracket the measured number.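

In this assay, among these compounds, compound 4 gives the first exact number, 15300 nM, showing that a ring on this aromatic carbon, para to the methyl group, can produce a measurable result. The swap of 1H-imidazol-1-yl for 1H-pyrazol-4-yl, which keeps the same atoms but adds a hydrogen-bond donor, gives an at least 1.9-fold lower number from compound 3 to compound 4 (0.29 log units; that floor lies within the scatter), and the swaps from the other two rings give an at least 1.9-fold lower number from compound 2 to compound 4 (0.29 log units; that floor lies within the scatter) and an at least 1.9-fold lower number from compound 1 to compound 4 (0.29 log units; that floor lies within the scatter). These steps are floors and not full sizes, and the other three compounds remain at a limit of the assay: the limit of > 30000 nM in this assay, at which 3 of the 4 values shown sit.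

The compounds shown leave open whether the hydrogen-bond donor of the 1H-pyrazol-4-yl group matters at all, a question that a 1-methyl-1H-pyrazol-4-yl group on the same carbon would address. Going by these compounds, the full size of each step also stays open, as does the effect of an amine or a carboxylic acid in this place.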